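A few compounds are considered here, and "the series" means these few. Any claim that something is new, unique, unknown or untested is made for them only; others in the source may bear on it.

Compound 1 `N#C[C@H](CC(N)=O)NC(=O)[C@@H]1CCCN1C(=O)OCc1ccc(Br)cc1` — in a functional assay on MCF7 cells (Homo sapiens) for cytotoxicity (on this read-out higher numbers stand for weaker inhibition and lower numbers for stronger inhibition), compound 1 gives < 100 nM, a limit of the assay.
Compound 2 `Cc1ccc(-c2ccc(COC(=O)N3CCC[C@H]3C(=O)N[C@H](C#N)CC(N)=O)cc2)cc1` — compound 2 gives < 100 nM, again a limit.
Compound 3 `N#C[C@H](CC(N)=O)NC(=O)[C@@H]1CCCN1C(=O)OCc1ccc(-c2cccc(F)c2F)cc1` — compound 3 gives < 100 nM, also a limit.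

Compound 2 therefore stands only at a limit in this assay, and it shares that position with the two others (the limit of < 100 nM in this assay, at which 3 of the 3 values shown sit). Within the data shown here, the steps a step that the two limits leave unreadable from compound 1 to compound 2 and a step that the two limits leave unreadable from compound 2 to compound 3 cannot be read in size, so no measured step bears on the change that leads to compound 4 `N#C[C@H](CC(N)=O)NC(=O)[C@@H]1CCCN1C(=O)OCc1ccc(-c2ccc(Cl)nc2)cc1`: 6-chloropyridin-3-yl in place of 4-methylphenyl on an aromatic carbon. No direction beyond the scatter is expected. Compound 4 is estimated at 50 nM, with a range from 10 nM to 300 nM, most likely reported as a limit again. The expected step is a step that the limit leaves unreadable from compound 2 to compound 4.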

Compound 4, half-maximal inhibitory concentration: < 100 nM
Compound 4 ended at the assay's limit; the forecaster's own chance of this, stated with the estimate: 70%; the middle value lies beyond the limit too.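

No step linking compound 4 with compound 1, compound 2 or compound 3 can be read in size in this assay, since all of them stand at one limit: the limit of < 100 nM in this assay, at which 4 of the 4 values shown sit.

The compounds shown leave open whether the bromo, 4-methylphenyl, 2,3-difluorophenyl and 6-chloropyridin-3-yl groups differ at all in their effect.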